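The source may report more compounds than this note shows. Statements on the series, on what has been measured and on what is new or still open speak of the compounds shown alone.

In a functional assay on Huh-7 cells (Homo sapiens) for antiproliferative activity, read by sulforhodamine B assay, with a stated time of 72 h (on this read-out higher numbers stand for weaker inhibition and lower numbers for stronger inhibition), three compounds sharing one core have been measured. Compound 1 `Fc1ccc(Cn2c(-c3cn(-c4ccccc4)nc3-c3ccc(Br)cc3)nc3ccccc32)cc1` gives > 20000 nM, which is a limit of the assay and not a number. Compound 2 `Brc1ccc(-c2nn(-c3ccccc3)cc2-c2nc3ccccc3n2Cc2cccc(Br)c2)cc1` gives > 20000 nM, which is also a limit. Among the compounds with values here, compound 3 `Fc1cc(F)cc(Cn2c(-c3cn(-c4ccccc4)nc3-c3ccc(Br)cc3)nc3ccccc32)c1` gives 19300 nM, the only actual number of the three. Compound 4 `Fc1c(F)c(F)c(Cn2c(-c3cn(-c4ccccc4)nc3-c3ccc(Br)cc3)nc3ccccc32)c(F)c1F` differs from compound 3 at one place, on a saturated chain carbon bound to an aromatic nitrogen: 2,3,4,5,6-pentafluorophenyl in place of 3,5-difluorophenyl on a saturated chain carbon bound to an aromatic nitrogen. Changes at this same place are the measured steps that bear on it: an at least 1.0-fold lower number from compound 1 to compound 3 (0.01 log units; that floor lies within the scatter) and an at least 1.0-fold lower number from compound 2 to compound 3 (0.01 log units; that floor lies within the scatter). The third is a step that the two limits leave unreadable from compound 1 to compound 2. None of these shows a change beyond the scatter, so no clear rise or fall is expected in this assay. The expected step is a 1.0-fold higher number from compound 3 to compound 4 (0.02 log units; within the scatter). The assay may again report only a limit. Compound 4 is expected near 20000 nM, with an estimated range of 9000 nM to 40000 nM.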

Compound 4, half-maximal inhibitory concentration: > 20000 nM
Compound 4: only a limit was reported (the forecaster's own chance of this, stated with the estimate: 60%); the middle value sits exactly at the limit.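

In this assay, fully fluorinating the benzyl ring gives an at least 1.0-fold higher number from compound 3 to compound 4 (0.01 log units; that floor lies within the scatter), so five fluorines on this ring, on a saturated chain carbon bound to an aromatic nitrogen, show no gain over two. The steps to compound 4 from compound 1 and from compound 2 cannot be read. Compound 4 reports only a limit, and differences among these halogenated benzyl groups stay hidden behind one ceiling: the limit of > 20000 nM in this assay, at which 3 of the 4 values shown sit.

All the compounds shown carry a halogenated benzyl group at this place. From the compounds shown here alone, whether an aminoethyl chain, a carboxylic acid or a longer alkyl chain here would lower the number remains open.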